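The compounds below may be only part of what the source reports. "The series", "measured", "known", "first", "only" and "open" are said of these compounds alone.

Compound 1 `[SeH]c1nc([SeH])c2ccccc2n1` and compound 3 `[SeH]c1nc([SeH])c2cccnc2n1` each carry two selenol groups on a fused bicyclic core; the difference between the two cores is not broken down here. In a functional assay on MCF7 cells (Homo sapiens) for cytotoxicity, read by MTT assay, with a stated time of 72 h (a higher number here means that more compound is tolerated, a lower number that less compound is tolerated), compound 3 gives 82700 nM. Compound 1 reaches only the limit of this assay, > 100000 nM. Compound 2 `Nc1nc([SeH])nc2ncccc12` is derived from compound 3. Compound 2 likewise gives only the limit, > 100000 nM. The change from compound 3 to compound 2 is one nitrogen atom in place of one selenium atom, on an aromatic carbon, and it produced an at least 1.2-fold higher number from compound 3 to compound 2 (0.08 log units; that floor lies within the scatter); the floor of that step follows from the limit of > 100000 nM in this assay, at which 2 of the 3 values shown sit. Compound 4 `Nc1nc([SeH])nc2ccccc12` is not yet measured; it arises from compound 1 by one nitrogen atom in place of one selenium atom, on an aromatic carbon, the same change made on the other core, with the same surroundings at the place of the change. Compound 1 already stands at the limit > 100000 nM. Resting on that and on the measured step of an at least 1.2-fold higher number from compound 3 to compound 2 (0.08 log units; that floor lies within the scatter), compound 4 is expected near 150000 nM. The step from compound 1 to compound 4 is thus expected to be a step that the limit leaves unreadable from compound 1 to compound 4. For compound 4 the expected range runs from 70000 nM to 400000 nM, most probably reported again as a limit.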

Compound 4, concentration lethal to 50% of the cells: > 100000 nM
Compound 4 gave a limit, no number; the forecaster's own chance of this, stated with the estimate: 75%; the middle value is on the limit's open side.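

Compound 4 reaches only a limit in this assay, > 100000 nM. No step between compound 1 and compound 4 can be read, because both stand at a limit: the limit of > 100000 nM in this assay, at which 3 of the 4 values shown sit.

The compounds shown leave open whether compound 1 and compound 4 differ at all in this assay, and by how much.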